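Chain length and ring swap in antiproliferative pyrazine nitriles

This account rests on a few compounds, and the source may have more. Where it says the series, first, only, none or still open, it means among the compounds named here.

Measured compounds:
compound 1 `CN(C)CCn1c(N)c(-c2nc3ccccc3[nH]2)c2nc(C#N)c(C#N)nc21` — 6340 nM
compound 2 `CN(C)CCCn1c(N)c(-c2nc3ccccc3[nH]2)c2nc(C#N)c(C#N)nc21` — 1730 nM
compound 3 `CN(C)CCCn1c(N)c(-c2nc3ccccc3s2)c2nc(C#N)c(C#N)nc21` — 1800 nM

The three measured compounds share a core and were tested in a functional assay on K562 cells (Homo sapiens) for antiproliferative activity, read by MTT assay, with a stated time of 48 h; on this read-out higher numbers stand for weaker inhibition and lower numbers for stronger inhibition. Compound 1 `CN(C)CCn1c(N)c(-c2nc3ccccc3[nH]2)c2nc(C#N)c(C#N)nc21` gives 6340 nM in this assay. Compound 2 `CN(C)CCCn1c(N)c(-c2nc3ccccc3[nH]2)c2nc(C#N)c(C#N)nc21` differs from it in one place, ((dimethylamino)methyl in place of dimethylamino on a saturated chain carbon, two bonds along the chain from an aromatic nitrogen), and gives 1730 nM; the step is a 3.7-fold lower number from compound 1 to compound 2 (0.56 log units; beyond the scatter). Compound 3 `CN(C)CCCn1c(N)c(-c2nc3ccccc3s2)c2nc(C#N)c(C#N)nc21` carries a different ring at the same position, and compound 3 gives 1800 nM; the step is a 1.0-fold higher number from compound 2 to compound 3 (0.02 log units; within the scatter). The difference between the cores of compound 1 and compound 3 is not broken down here.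

Compound 4 `CN(C)CCCCn1c(N)c(-c2nc3ccccc3s2)c2nc(C#N)c(C#N)nc21` has not yet been measured. It differs from compound 3 by (dimethylamino)methyl in place of dimethylamino on a saturated chain carbon, three bonds along the chain from an aromatic nitrogen. This is the same kind of change as that from compound 1 to compound 2, but the place is not the same: there it sits two bonds along the chain from an aromatic nitrogen, here three bonds. For the measured compounds named here, because a 3.7-fold lower number from compound 1 to compound 2 (0.56 log units; beyond the scatter), a lower number is expected for compound 4 as well, though the single earlier step gives little ground to expect it to be as large again, so the expected step is a 1.5-fold lower number from compound 3 to compound 4 (0.18 log units; within the scatter). Compound 4 is estimated at 1200 nM, with a range from 500 nM to 3000 nM.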

Compound 4, half-maximal inhibitory concentration: 1330 nM
For compound 4 the middle estimate is 1.1-fold (0.04 log units) below the measured one; low and high end bracket the measured number.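

In this assay, the change from 3-(dimethylamino)propyl to 4-(dimethylamino)butyl on the core of compound 3 gives a 1.4-fold lower number from compound 3 to compound 4 (0.13 log units; within the scatter), so this step does not separate the two compounds. The same kind of change therefore did not carry over at its earlier size, and the two steps differ: the same change on two cores in this assay, a 3.7-fold lower number (0.56 log units; beyond the scatter) from compound 1 to compound 2 and a 1.4-fold lower number (0.13 log units; within the scatter) from compound 3 to compound 4, 2.7-fold (0.43 log units) apart, beyond the scatter of two such steps What this does not show is where the gap comes from: the two steps differ both in the core and in the place of the change, two bonds along the chain from an aromatic nitrogen in the earlier step and three bonds in the new one, and with a single pair for each, the data cannot tell these two apart.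

The compounds shown leave open how 4-(dimethylamino)butyl would read with 1H-benzimidazol-2-yl, and how 2-(dimethylamino)ethyl would read with 1,3-benzothiazol-2-yl, either of which would help to separate the ring from the chain length. Also open, from the compounds shown here alone, is how a longer chain than 4-(dimethylamino)butyl, or a morpholine or piperidine ring in place of dimethylamino, would read in this assay.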